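Notes on the aryl group on the ring nitrogen

A few compounds are considered here, and "the series" means these few. Any claim that something is new, unique, unknown or untested is made for them only; others in the source may bear on it.

Within the data shown here, compound 3 `O=c1oc2ccccc2c(N2CCN(c3ccc(Cl)c(Cl)c3)CC2)c1CO` is the one member of this small set with a number in a functional assay on WM1361 cells (Homo sapiens) for inhibition, read by MTT assay, with a stated time of 24 h; a higher number here means a weaker inhibitor, a lower number a stronger inhibitor: compound 3 gives 42700 nM. Compound 1 `CCN1CCN(c2c(CO)c(=O)oc3ccccc23)CC1` carries an ethyl on the ring nitrogen; in this assay compound 1 reaches only a limit of the assay, > 100000 nM. Compound 2 `O=c1oc2ccccc2c(N2CCN(c3ccccc3F)CC2)c1CO` carries a 2-fluorophenyl there; in this assay compound 2 likewise stops at a limit, > 50000 nM. The steps toward compound 3 are an at least 2.3-fold lower number from compound 1 to compound 3 (0.36 log units; beyond the scatter) and an at least 1.1-fold lower number from compound 2 to compound 3 (0.06 log units; that floor lies within the scatter); the step that the two limits leave unreadable from compound 1 to compound 2 cannot be read because of the limit of > 100000 nM in this assay, at which 1 of the 3 values shown sits, and (the limit of > 50000 nM in this assay, at which 1 of the 3 values shown sits).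

Compound 4 `COc1ccc(N2CCN(c3c(CO)c(=O)oc4ccccc34)CC2)cc1` differs from compound 3 in one place: 4-methoxyphenyl in place of 3,4-dichlorophenyl on an amine nitrogen in a ring. Among the measured compounds shown here, the only aryl-for-aryl exchange measured, an at least 1.1-fold lower number from compound 2 to compound 3 (0.06 log units; that floor lies within the scatter), has a floor within the scatter and so sets no firm direction; the larger step of an at least 2.3-fold lower number from compound 1 to compound 3 (0.36 log units; beyond the scatter) concerns ethyl and does not bear directly on this change. Compound 3 itself already sits close to the limits at which its neighbours stop. The expected step of a 1.5-fold higher number from compound 3 to compound 4 (0.18 log units; within the scatter) is therefore small, leaning toward a higher number, with a real chance that compound 4 returns only a limit. The estimated value for compound 4 in this assay is 65000 nM, within a range of 25000 nM to 200000 nM.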

Compound 4, half-maximal inhibitory concentration: 40400 nM
The estimate for compound 4 lay 1.6-fold (0.21 log units) above the measured number, and the stated range covers the measured number.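

Compound 4 gives the series a second number in this assay, and a 1.1-fold lower number from compound 3 to compound 4 (0.02 log units; within the scatter) shows that 4-methoxyphenyl and 3,4-dichlorophenyl on the ring nitrogen cannot be told apart here, although the entering group carries a hydrogen-bond acceptor and the leaving group none. The exchange of ethyl for an aryl group now has two readings beyond the scatter: an at least 2.4-fold lower number from compound 1 to compound 4 (0.39 log units; beyond the scatter) joins the step from ethyl to 3,4-dichlorophenyl, so that the pattern holds for compound 3 and compound 4. Compound 2 neither supports nor goes against this pattern, and its place among the aryl groups stays unsettled, since an at least 1.2-fold lower number from compound 2 to compound 4 (0.09 log units; that floor lies within the scatter) shows no firm difference between 2-fluorophenyl and 4-methoxyphenyl.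

Still open, from the compounds shown here alone, is whether a group of another kind on the ring nitrogen, such as a benzyl, a longer alkyl chain or a carboxylic acid, would move the number further than these aryl groups do. The step from compound 1 to compound 2 still cannot be read, and the value of compound 1 is a limit: the limit of > 100000 nM in this assay, at which 1 of the 4 values shown sits.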